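A Halogen Swap in a Weakly Antiproliferative Series

The source may hold more compounds than are shown below. What is called first, only, known or untested is meant among the compounds shown, and "the series" means these compounds.

In a functional assay on HeLa cells (Homo sapiens) for antiproliferative activity, read by MTT assay, with a stated time of 72 h (a higher number here means a weaker inhibitor, a lower number a stronger inhibitor), compound 1 `COc1nc(OC)c2c(ccn2C/C=C2\OC(=O)C(OCc3ccccc3)=C2OCc2ccccc2)n1` gives 12000 nM. Compound 2 `O=C1O/C(=C\Cn2cnc3c(F)nc(F)c(Cl)c32)C(OCc2ccccc2)=C1OCc1ccccc1` reaches only the limit of the measurement, recorded as > 100000 nM. Compound 2 thus sits at the limit of > 100000 nM in this assay, at which 1 of the 2 values shown sits, so no number marks its own place, and the gap between it and compound 1 cannot be stated as a step. Compound 3 `O=C1O/C(=C\Cn2cnc3cncc(Br)c32)C(OCc2ccccc2)=C1OCc1ccccc1` has not been measured in this assay. It differs from compound 2 in one place: a group of 10 heavy atoms (6 carbon, 3 nitrogen, 1 bromine; one five-membered aromatic ring with 2 hetero atoms, one six-membered aromatic ring with 1 hetero atom) in place of a group of 12 heavy atoms (6 carbon, 3 nitrogen, 2 fluorine, 1 chlorine; one five-membered aromatic ring with 2 hetero atoms, one six-membered aromatic ring with 1 hetero atom), on a saturated chain carbon bound to a double-bonded chain carbon. Going by the values given here, no pair of measured compounds differing in a single place is available, so the size of this step cannot be read from data; compound 1 shows that a different group on a saturated chain carbon bound to a double-bonded chain carbon can give a measurable number, while compound 2 shows that another does not. The step of an at least 1.6-fold lower number from compound 2 to compound 3 (0.22 log units; that floor lies within the scatter) is expected to be modest, pointing towards somewhat stronger inhibition but hardly beyond the scatter. Compound 3 is therefore estimated at 60000 nM, with a likely range from 15000 nM to 200000 nM, and a real chance that this assay again reports only a limit.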

Compound 3, half-maximal inhibitory concentration: 15000 nM
The estimate for compound 3 lay 4.0-fold (0.60 log units) above the measured number, and the stated range covers the measured number.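

In this assay, the group of 10 heavy atoms with its 1 bromine, in place of the group of 12 heavy atoms with its 2 fluorine and 1 chlorine, gives an at least 6.6-fold lower number from compound 2 to compound 3 (0.82 log units; beyond the scatter), which shows that a change in this one place, on a saturated chain carbon bound to a double-bonded chain carbon, can separate a compound with a measurable number from one without. Compound 2 stands at a limit and not at a number, so the size of this step is only a floor: the limit of > 100000 nM in this assay, at which 1 of the 3 values shown sits. With compound 3 at 15000 nM, this place now carries a second group that gives a measurable number, after compound 1 at 12000 nM.

The fluorine, chlorine and bromine atoms change together in this step, so the compounds shown leave open which of these atoms accounts for it. They also leave open how this assay would read for a group in this place that carries an amine or a carboxylic acid in place of the halogen.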